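The source may report more compounds than this note shows. Statements on the series, on what has been measured and on what is new or still open speak of the compounds shown alone.

Working notes on the series. The shared core is kept throughout and varied at a single aromatic carbon. Compound 1 `Cc1nn(-c2nc(-c3ccc(Cl)c(Cl)c3)c(SC(C)C)s2)c(C(=O)O)c1-c1cncnc1` gives 22000 nM in a functional assay on BJAB cells (Homo sapiens) for antiproliferative activity, with a stated time of 4 days; on this read-out lower numbers stand for an effect already at smaller amounts and higher numbers for an effect only at larger amounts of compound; compound 2 `Cc1nn(-c2nc(-c3ccc(Cl)c(Cl)c3)c(SC(C)C)s2)c(C(=O)O)c1-c1ccc(C(F)(F)F)cc1` gives 3500 nM in this assay; compound 3 `Cc1nn(-c2nc(-c3ccc(Cl)c(Cl)c3)c(SC(C)C)s2)c(C(=O)O)c1Cc1ccccc1[N+](=O)[O-]` gives 20000 nM in this assay. Compound 3 thus stands second highest of the three numbers: its gap to compound 1, a 1.1-fold lower number from compound 1 to compound 3 (0.04 log units; within the scatter), lies within the scatter, whereas its gap to compound 2, a 5.7-fold higher number from compound 2 to compound 3 (0.76 log units; beyond the scatter), lies beyond it, and compound 2 holds the lowest number of the set.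

Compound 4 `Cc1nn(-c2nc(-c3ccc(Cl)c(Cl)c3)c(SC(C)C)s2)c(C(=O)O)c1-c1cc(C#N)cc(C(F)(F)F)c1` is not yet measured. The change from compound 3 is 3-cyano-5-(trifluoromethyl)phenyl in place of 2-nitrobenzyl on an aromatic carbon. Among the compounds with values here, the step that bears most directly on it is the one from compound 2 to compound 3, a 5.7-fold higher number from compound 2 to compound 3 (0.76 log units; beyond the scatter), since compound 2 also carries a trifluoromethyl-bearing phenyl on an aromatic carbon of the five-membered aromatic ring with 2 nitrogen; the step of a 6.3-fold lower number from compound 1 to compound 2 (0.80 log units; beyond the scatter) points the same way for a trifluoromethyl-bearing phenyl. Going back from the benzyl to a phenyl of that kind, a modest lower number is therefore expected for compound 4, roughly a 5.0-fold lower number from compound 3 to compound 4 (0.70 log units; beyond the scatter). The estimate for compound 4 is 4000 nM, with a range from 1500 nM to 12000 nM.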

Compound 4, half-maximal effective concentration: 3600 nM
Compound 4: the middle estimate sits 1.1-fold (0.05 log units) above what was measured; low and high end bracket the measured number.
By their numbers in this assay, from the lowest: compounds 2 and 4 (each within the scatter of the next); then compounds 3 and 1 (each within the scatter of the next).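

In this assay, 3-cyano-5-(trifluoromethyl)phenyl and 4-(trifluoromethyl)phenyl cannot be told apart at this carbon next to the ring atom that bears a carboxy group (a 1.0-fold higher number from compound 2 to compound 4 (0.01 log units; within the scatter)), so a nitrile and a different placing of the trifluoromethyl group together leave the number within the scatter. The new compound also separates from the other two groups, with the same result against 2-nitrobenzyl (a 5.6-fold lower number from compound 3 to compound 4 (0.74 log units; beyond the scatter)) and against pyrimidin-5-yl (a 6.1-fold lower number from compound 1 to compound 4 (0.79 log units; beyond the scatter)), so the four compounds fall into two pairs: the two trifluoromethyl-bearing phenyls on the low side and the other two groups on the high side, with no compound shown going against this split. Nothing at hand gives a reason for this split.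

Still open, as far as these compounds go, is whether the trifluoromethyl group is needed at all, which a plain phenyl or a phenyl carrying only a nitrile would separate from the effect of the ring itself. Also open, from the compounds shown here alone, is whether the number of compound 3 follows from its methylene link or from its nitro group, a question for a plain benzyl, a 2-nitrophenyl or a benzyl carrying an amine.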